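Furan-2-yl Replacing 3-Fluorophenyl: Expected Tolerability in Liver Cells

This account rests on a few compounds, and the source may have more. Where it says the series, first, only, none or still open, it means among the compounds named here.

Compound 1 `N#Cc1ccc(-c2cc(Cl)cn3c([N+](=O)[O-])c(CS(=O)(=O)c4ccccc4)nc23)cc1`: > 3900 nM
Compound 2 `O=[N+]([O-])c1c(CS(=O)(=O)c2ccccc2)nc2c(-c3cccc(CO)c3)cc(Cl)cn12`: > 25000 nM
Compound 3 `O=[N+]([O-])c1c(CS(=O)(=O)c2ccccc2)nc2c(-c3cccc(F)c3)cc(Cl)cn12`: > 12500 nM

In an ADME assay on HepG2 cells (Homo sapiens) for cytotoxicity, read by MTT assay, with a stated time of 72 h (a higher number here means that more compound is tolerated, a lower number that less compound is tolerated), none of the three measured compounds gave a number; each stopped at a limit of the assay. Compound 3 reached the limit (the limit of > 12500 nM in this assay, at which 1 of the 3 values shown sits). Compound 2 reached the limit (the limit of > 25000 nM in this assay, at which 1 of the 3 values shown sits). Compound 1 reached the limit (the limit of > 3900 nM in this assay, at which 1 of the 3 values shown sits). So compound 3 stands only at a limit, and the steps a step that the two limits leave unreadable from compound 1 to compound 2, a step that the two limits leave unreadable from compound 1 to compound 3 and a step that the two limits leave unreadable from compound 2 to compound 3 cannot be read in size. Compound 4 `O=[N+]([O-])c1c(CS(=O)(=O)c2ccccc2)nc2c(-c3ccco3)cc(Cl)cn12` brings the change (furan-2-yl in place of 3-fluorophenyl on an aromatic carbon). Among the measured compounds shown here, no measured step bears on this change in readable size, so no step beyond the scatter is expected, with a step that the limit leaves unreadable from compound 3 to compound 4 as the expected step. Compound 4 is estimated at 15000 nM, with a range from 4000 nM to 50000 nM, most likely again reported as a limit.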

Compound 4, half-maximal cytotoxic concentration: > 3900 nM
Compound 4 ended at the assay's limit; the forecaster's own chance of this, stated with the estimate: 80%; the middle value does not contradict the limit.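

In this assay compound 4 gives > 3900 nM, which is a limit. Its steps from compound 1, compound 2 and compound 3 therefore cannot be read in size. The compounds shown leave open how much of each compound the cells actually tolerate, and whether exchanging these groups changes that tolerance at all.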